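Cyclobutyl side-chain variation in an EP4 agonist series

The compounds below may be only part of what the source reports. "The series", "measured", "known", "first", "only" and "open" are said of these compounds alone.

Compound 1 `CCCCC1([C@H](O)/C=C/[C@H]2COC(=O)N2CCSc2nc(C(=O)O)cs2)CCC1` gives 73 nM in an assay on isolated protein for agonist activity at prostaglandin E2 receptor EP4 subtype (Homo sapiens); a lower number here means that less compound is needed, a higher number that more compound is needed for the effect; compound 2 `CC(C)(C)CCC1([C@H](O)/C=C/[C@H]2COC(=O)N2CCSc2nc(C(=O)O)cs2)CCC1` gives 4710 nM; compound 3 `O=C(O)c1csc(SCCN2C(=O)OC[C@@H]2/C=C/[C@@H](O)C2(CCCCF)CCC2)n1` gives 195 nM, second highest of the three and nearest to compound 1, as a 2.7-fold higher number from compound 1 to compound 3 (0.43 log units; beyond the scatter) shows. Compound 4 `O=C(O)c1csc(SCCN2C(=O)OC[C@@H]2/C=C/[C@@H](O)C2(CCc3ccccc3)CCC2)n1` carries phenyl in place of 2-fluoroethyl on a saturated chain carbon, two bonds along the chain from a saturated ring carbon. The step that bears most directly is a 65-fold higher number from compound 1 to compound 2 (1.81 log units; beyond the scatter), a large loss when a bulkier group enters at the same place, and a 24-fold lower number from compound 2 to compound 3 (1.38 log units; beyond the scatter) recovers most of it. Phenyl at that position is therefore expected to cost potency in this assay, though less severely than tert-butyl did; the expected step is a 2.6-fold higher number from compound 3 to compound 4 (0.41 log units; beyond the scatter). Compound 4 is estimated at 500 nM, within 120 nM to 2500 nM.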

Compound 4, half-maximal effective concentration: 465 nM
Compound 4: middle estimate off by 1.1-fold (0.03 log units), on the high side, within the range that was stated.
By their numbers in this assay, from the lowest: compound 1; then compound 3; then compound 4; then compound 2.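

In this assay, phenyl at this position, on a saturated chain carbon, two bonds along the chain from a saturated ring carbon, does not carry the full loss seen with tert-butyl: a 10-fold lower number from compound 2 to compound 4 (1.01 log units; beyond the scatter). Phenyl still falls short of the smaller groups, with a 2.4-fold higher number from compound 3 to compound 4 (0.38 log units; beyond the scatter) and a 6.4-fold higher number from compound 1 to compound 4 (0.80 log units; beyond the scatter). Nothing available explains this order.

Open, going by these compounds, is whether a pyridine ring in place of phenyl, or a methoxy group on the phenyl ring, would bring the number closer to that of compound 1. On these data alone, a longer chain ending in phenyl also remains open.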